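Replacing phenyl with furan-2-yl on a carbonyl carbon

The compounds below may be only part of what the source reports. "The series", "measured", "known", "first", "only" and "open" are said of these compounds alone.

In a functional assay on TSGH 9201 cells (Homo sapiens) for cytotoxicity (a lower number here means a stronger inhibitor, a higher number a weaker inhibitor), compound 1 `COc1ccc(S(=O)(=O)N2CCc3cccc(NC(=O)c4cccs4)c32)cc1` gives 54 nM and compound 2 `COc1ccc(S(=O)(=O)N2CCc3cccc(NC(=O)c4ccc(F)cc4)c32)cc1` gives 100 nM while compound 3 `COc1ccc(S(=O)(=O)N2CCc3cccc(NC(=O)c4ccccc4)c32)cc1` gives 201 nM on the same core. Two steps fix the place of that last value: a 2.0-fold higher number from compound 2 to compound 3 (0.30 log units; within the scatter) and a 3.7-fold higher number from compound 1 to compound 3 (0.57 log units; beyond the scatter) on the other side. Compound 3 therefore cannot be told apart from compound 2 but does stand apart from compound 1.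

The unmeasured compound 4 `COc1ccc(S(=O)(=O)N2CCc3cccc(NC(=O)c4ccco4)c32)cc1` carries furan-2-yl in place of phenyl on a carbonyl carbon with the rest of the structure unchanged. The nearest guide is compound 1, whose thiophen-2-yl sits at the same carbonyl carbon, and the modest 3.7-fold higher number from compound 1 to compound 3 (0.57 log units; beyond the scatter) shows that this place responds to the choice of ring. The step of a 1.9-fold higher number from compound 1 to compound 2 (0.27 log units; within the scatter) adds little, as it stays within the scatter. Going by the values given here, no furan-2-yl compound has been measured, so only part of the thiophen-2-yl difference is expected to carry over. A small step towards a lower number is expected, estimated as a 2.0-fold lower number from compound 3 to compound 4 (0.30 log units; within the scatter) in this series. For compound 4 the estimate is 100 nM with a range of 40 nM to 250 nM expected in this assay on measurement.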

Compound 4, half-maximal inhibitory concentration: 11.1 nM
For compound 4 the middle estimate is 9.0-fold (0.95 log units) above the measured one, outside the stated range (below it).
By their numbers in this assay, from the lowest: compound 4; then compounds 1, 2 and 3 (each within the scatter of the next, the first and the last beyond it).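

In this assay, the furan-2-yl amide compound 4 stands apart from all three earlier compounds and is the strongest inhibitor of the four (against the benzamide, an 18-fold lower number from compound 3 to compound 4 (1.26 log units; beyond the scatter); against the 4-fluorophenyl amide, a 9.0-fold lower number from compound 2 to compound 4 (0.95 log units; beyond the scatter); against the thiophen-2-yl amide, a 4.9-fold lower number from compound 1 to compound 4 (0.69 log units; beyond the scatter)). The earlier compounds had shown only a modest response to the ring on this carbonyl carbon (at most a 3.7-fold higher number from compound 1 to compound 3 (0.57 log units; beyond the scatter)), whereas the large step from phenyl to furan-2-yl shows that this place can respond much more widely than those compounds suggested. The two five-membered aromatic rings are also not interchangeable, since furan-2-yl and thiophen-2-yl lie beyond the scatter of each other, so ring size alone does not set the result in this small set.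

As far as these compounds go, what remains open is whether the response extends to other rings at this carbonyl carbon, such as pyridin-2-yl or a furan-2-yl ring carrying a methyl group or a bromine atom, and whether the gain would survive a change elsewhere on the shared core. Nothing available here explains the result.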